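Replacing ethyl with 1,3-oxazol-4-yl in a half-life series

The source may report more compounds than this note shows. Statements on the series, on what has been measured and on what is new or still open speak of the compounds shown alone.

Three compounds have so far been followed in an ADME assay on microsomes (Homo sapiens) for metabolic stability (a higher number here means that the compound lasts longer, a lower number that the compound disappears faster), as their measure of survival. Compound 2 `CCC(=O)N1CCC(C(=O)N2N=CCC2c2ccccc2)CC1` gives > 2.75 h as a limit of the assay, not a number. Compound 1 `O=C(c1cscn1)N1CCC(C(=O)N2N=CC[C@H]2c2ccccc2)CC1` gives > 3 h as a limit too. Compound 3 `CC(C)(CO)C(=O)N1N=CCC1c1ccccc1` gives > 1.5 h as a limit as well. Compound 2 therefore has no exact value, and neither do the other two, so the three cannot be put in order.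

The next compound, compound 4 `O=C(c1cocn1)N1CCC(C(=O)N2N=CCC2c2ccccc2)CC1`, differs from compound 2 in one place, with 1,3-oxazol-4-yl in place of ethyl on a carbonyl carbon. The same difference can be read as propanoyl to (1,3-oxazol-4-yl)carbonyl.

Among the measured compounds shown here, no measured pair here shows what a single change does, so the expectation is a cautious one: no step beyond the usual scatter, in either direction. The closest guide is compound 1, which gives > 3 h as its limit. The estimated half-life for compound 4 is 3 h in this assay, with an expected range from 1.5 h to 6 h as its span. This estimate means an expected step that the limit leaves unreadable from compound 2 to compound 4 in size, and the assay may well report only a limit again.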

Compound 4, half-life: > 2.75 h
Compound 4: a limit, no number; the forecaster's own chance of this, stated with the estimate: 65%; the middle value lies beyond the limit too.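

In this assay compound 4 gives > 2.75 h, which is a limit and not a number. Compound 2 gives > 2.75 h, also a limit. Among the compounds shown here, no step can therefore be read between compound 2 and compound 4. The compounds shown leave open whether 1,3-oxazol-4-yl in place of ethyl on a carbonyl carbon changes the half-life at all, and in which direction.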